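Vinyl to Allyl on the Chain of Compound 1

A few compounds are considered here, and "the series" means these few. Any claim that something is new, unique, unknown or untested is made for them only; others in the source may bear on it.

Compound 1 `C=CCCCCOc1ccccc1-c1cnc(OCCC=C)n1C` is the strongest inhibitor measured so far in a functional assay on A549 cells (Homo sapiens) for inhibition, read by colorimetric assay and MTT assay, with a stated time of 72 h (a lower number here means a stronger inhibitor, a higher number a weaker inhibitor), where compound 1 gives 9000 nM. Alongside it, compound 2 `C=CCCCCOc1ccc(C)cc1-c1cnc(OCCC=C)n1C` gives 59000 nM and compound 3 `C=CCCCCOc1ccc(F)cc1-c1cnc(OCCC=C)n1C` gives 61000 nM.

Compound 4 `C=CCCCCOc1ccccc1-c1cnc(OCCCC=C)n1C` has not yet been measured. It carries allyl in place of vinyl on a saturated chain carbon, two bonds along the chain from an oxygen on an aromatic ring. Put another way, (but-3-en-1-yl)oxy becomes (pent-4-en-1-yl)oxy.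

Among the compounds with values here, no measured step touches this chain, so the evidence is only indirect. Methyl in place of hydrogen on an aromatic carbon gave a 6.6-fold higher number from compound 1 to compound 2 (0.82 log units; beyond the scatter), and fluoro in place of hydrogen on an aromatic carbon gave a 6.8-fold higher number from compound 1 to compound 3 (0.83 log units; beyond the scatter). Exchanging those two groups gave a 1.0-fold higher number from compound 2 to compound 3 (0.01 log units; within the scatter). These steps show that a small change to compound 1 can shift the number, and that both changes to it raised the number. They sit at a different place, however, so they guide the direction and size only loosely.

A small upward change is therefore expected, a 1.3-fold higher number from compound 1 to compound 4 (0.12 log units; within the scatter), and it may not clear the scatter. In this assay the estimated value for compound 4 is 12000 nM, with an expected range of 4000 nM to 40000 nM.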

Compound 4, half-maximal inhibitory concentration: 3000 nM
Compound 4: middle estimate off by 4.0-fold (0.60 log units), on the high side, and the stated range ends above it.
By their numbers in this assay, from the lowest: compound 4; then compound 1; then compounds 2 and 3 (each within the scatter of the next).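

Lengthening (but-3-en-1-yl)oxy to (pent-4-en-1-yl)oxy gave a 3.0-fold lower number from compound 1 to compound 4 (0.48 log units; beyond the scatter) in this assay, so this chain, which no earlier step touched, does respond to change. The direction is opposite to that of the two changes on the aromatic ring, which gave a 6.6-fold higher number from compound 1 to compound 2 (0.82 log units; beyond the scatter) and a 6.8-fold higher number from compound 1 to compound 3 (0.83 log units; beyond the scatter), so compound 1 is not a ceiling that every change makes worse. Allyl and vinyl differ only in their count of carbons, with the same count of double bonds outside aromatic rings and no ring, hydrogen-bond donor, hydrogen-bond acceptor or net charge on either side, yet that small change moved the number beyond the scatter, and nothing available accounts for the drop.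

On these data alone, with a single step at this position, it remains open whether a longer chain would lower the number further, or whether a saturated chain without the double bond, or an amine at the chain end, would do as well. As far as these compounds go, it also remains open whether the methyl and fluoro changes on the aromatic ring would raise the number as they did before if combined with the (pent-4-en-1-yl)oxy chain of compound 4.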